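Cyclopentyl to Cyclohexyl: the Expected Shift for Compound 4

The source may report more compounds than this note shows. Statements on the series, on what has been measured and on what is new or still open speak of the compounds shown alone.

Compound 3 `CCCn1c(=O)c2nn(C3CCCC3)nc2n(CCC)c1=O` holds the lowest number of the three measured compounds in an assay on cell membranes from brain for displacement of a labelled ligand from adenosine receptor A1 (Bos taurus) (a lower number here means a stronger inhibitor, a higher number a weaker inhibitor), where compound 3 gives 1300 nM. Compound 1 `Cn1c(=O)c2c(nnn2C2CCCC2)n(C)c1=O` gives 11000 nM in this assay, and compound 2 `Cn1c(=O)c2c(nnn2C2CCCCC2)n(C)c1=O` gives 23000 nM; compound 1 stands nearest to compound 3 and compound 2 furthest, and both gaps lie beyond the scatter.

Compound 4 `CCCn1c(=O)c2nn(C3CCCCC3)nc2n(CCC)c1=O` differs from compound 3 in a single place: cyclohexyl in place of cyclopentyl on an aromatic nitrogen. The same exchange has been measured once among these compounds, in the pair of compound 1 and compound 2, where it produced a 2.1-fold higher number from compound 1 to compound 2 (0.32 log units; beyond the scatter). For the measured compounds named here, that step is modest, yet it lies beyond the scatter, and it is the only measured precedent for the change. Nothing in the data indicates that the propyl-bearing core of compound 3 would respond differently from the core of compound 1, so a step of similar size and direction is expected, namely a 2.1-fold higher number from compound 3 to compound 4 (0.32 log units; beyond the scatter). Going by the values given here, compound 4 is therefore estimated at 2700 nM in this assay, with a range from 1300 nM to 6000 nM, which allows for the step being somewhat smaller or larger than its single precedent.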

Compound 4, inhibition constant: 1600 nM
For compound 4 the middle estimate is 1.7-fold (0.23 log units) above the measured one, within the range that was stated.
By their numbers in this assay, from the lowest: compounds 3 and 4 (each within the scatter of the next); then compound 1; then compound 2.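

On the propyl-bearing core, cyclohexyl in place of cyclopentyl on the aromatic nitrogen gives a 1.2-fold higher number from compound 3 to compound 4 (0.09 log units; within the scatter) in this assay, so on this core the larger ring brings no readable change. For the compounds shown here, the earlier pair had offered only one reading of this exchange, a modest step beyond the scatter, and could not show whether that step would hold on another core. The second reading shows that this position accepts either ring on the propyl-bearing core, and the two readings cannot be told apart, so the data give no sign that the effect of the exchange depends on the core: the same change on two cores in this assay, a 2.1-fold higher number (0.32 log units; beyond the scatter) from compound 1 to compound 2 and a 1.2-fold higher number (0.09 log units; within the scatter) from compound 3 to compound 4, 1.7-fold (0.23 log units) apart, within the scatter of two such steps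

Only these two carbon rings appear at this position, which leaves open how an open chain such as n-butyl, an aromatic phenyl ring, or a cyclohexyl ring carrying an amine or a hydroxyl group would read in this assay. The core of compound 1 and the core of compound 3 differ in more than one place, so the compounds shown cannot assign the gap between those cores to the propyl chains alone, and a longer chain in their place remains an open question.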